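From an Acid Tail to an Ethylpiperidine Amide

A few compounds are considered here, and "the series" means these few. Any claim that something is new, unique, unknown or untested is made for them only; others in the source may bear on it.

Measured compounds:
compound 1 `CC(C)(C)c1ccc(C(=O)N2CCC3(CC2)C(=O)N(CC(=O)NCCC(=O)O)CN3c2ccccc2)cc1`: 11400 nM
compound 2 `CS(=O)(=O)NCCNC(=O)CN1CN(c2ccccc2)C2(CCN(C(=O)c3ccc(C4CCCCC4)cc3)CC2)C1=O`: 2100 nM

In an assay on HEK293 cells for displacement of a labelled ligand from NPC1-like intracellular cholesterol transporter 1 (Homo sapiens) (a lower number here means a stronger inhibitor, a higher number a weaker inhibitor), compound 1 gives 11400 nM, the highest of the two numbers, while compound 2 gives 2100 nM, a gap beyond the scatter. Compound 3 `CCC1CCCN(C(=O)CN2CN(c3ccccc3)C3(CCN(C(=O)c4ccc(C(C)(C)C)cc4)CC3)C2=O)C1` has not yet been measured. It differs from compound 1 in one place: 3-ethylpiperidin-1-yl in place of (2-carboxyethyl)amino on a carbonyl carbon. Among the compounds with values here, no measured pair shows this same change, so the expectation rests only on the two numbers at hand, which show that a lower number than that of compound 1 is reached. Compound 3 is therefore expected to give a lower number than compound 1, a step of a 6.3-fold lower number from compound 1 to compound 3 (0.80 log units; beyond the scatter), with an estimated 1800 nM and a range from 500 nM to 7000 nM.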

Compound 3, half-maximal inhibitory concentration: 3900 nM
The estimate for compound 3 lay 2.2-fold (0.34 log units) below the measured number, within the range that was stated.
By their numbers in this assay, from the lowest: compounds 2 and 3 (each within the scatter of the next); then compound 1.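

In this assay, within the data shown here, 3-ethylpiperidin-1-yl in place of (2-carboxyethyl)amino on a carbonyl carbon gives a 2.9-fold lower number from compound 1 to compound 3 (0.47 log units; beyond the scatter), a modest step and the first one-place comparison at this position. It shows that a ring group with no hydrogen-bond donors or acceptors is tolerated here and gives the lower number. Nothing measured accounts for the step.

The compounds shown leave open whether the step follows from the loss of the carboxylic acid, the piperidine ring or its ethyl group. An unsubstituted piperidin-1-yl or a simple amine on the same carbonyl carbon would help separate these.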